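From 4-nitrophenyl to pyridin-4-yl on compound 3

This account rests on a few compounds, and the source may have more. Where it says the series, first, only, none or still open, it means among the compounds named here.

compound 1 `COc1cc(-n2c(-c3cccc4cc[nH]c34)cccc2=O)cc(OC)c1OC` gives 138 nM
compound 2 `COc1ccc(-n2c(-c3cc(OC)c(OC)c(OC)c3)cccc2=O)cc1O` gives 1220 nM
compound 3 `COc1cc(-c2cccc(=O)n2-c2ccc([N+](=O)[O-])cc2)cc(OC)c1OC` gives 311 nM

All three values come from a functional assay on SK-OV-3 cells (Homo sapiens) for cytotoxicity, read by spectrophotometry, with a stated time of 72 h (a lower number here means a stronger inhibitor, a higher number a weaker inhibitor), in the same way. Compound 3 has the second highest of the three numbers, higher than that of compound 1 and lower than that of compound 2.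

Compound 4 `COc1cc(-c2cccc(=O)n2-c2ccncc2)cc(OC)c1OC` has not yet been measured. Its difference from compound 3 is pyridin-4-yl in place of 4-nitrophenyl on an aromatic nitrogen in full, which in short is pyridin-4-yl in place of 4-nitrophenyl on an aromatic nitrogen. Among the compounds with values here, one measured step bears on this place: a 3.9-fold lower number from compound 2 to compound 3 (0.59 log units; beyond the scatter) is a modest change, but one that lies beyond the scatter. Within the data shown here, no compound carrying pyridin-4-yl has been measured, so that step suggests a size and gives no firm direction. In this assay the expected step is of comparable size and more likely upward, estimated as a 2.9-fold higher number from compound 3 to compound 4 (0.46 log units; beyond the scatter) and resting on that single precedent. The estimate for compound 4 is 900 nM with an expected range of 200 nM to 4000 nM for four of five measurements.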

Compound 4, half-maximal inhibitory concentration: 3020 nM
For compound 4 the middle estimate is 3.4-fold (0.53 log units) below the measured one; the range from low to high includes it.
By their numbers in this assay, from the lowest: compound 1; then compound 3; then compound 2; then compound 4.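

Read in this assay, this step shows that the place on the aromatic nitrogen responds strongly to pyridin-4-yl, with a 9.7-fold higher number from compound 3 to compound 4 (0.99 log units; beyond the scatter) as the replacement for 4-nitrophenyl. The new group also compares poorly with 3-hydroxy-4-methoxyphenyl, with a 2.5-fold higher number from compound 2 to compound 4 (0.39 log units; beyond the scatter) at the same place, so among these three compounds pyridin-4-yl carries the highest number and 4-nitrophenyl the lowest. No measurement shown gives a reason for this rise.

The compounds shown leave open whether the step follows from the ring nitrogen of pyridin-4-yl or from the absence of the nitro group, since an unsubstituted phenyl or a pyridin-3-yl at this place does not appear among them. Going by these compounds, how a 4-aminophenyl or a 4-carboxyphenyl would behave here also remains unknown.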